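Amino in Place of Chloro: An Expectation for Compound 4

A few compounds are considered here, and "the series" means these few. Any claim that something is new, unique, unknown or untested is made for them only; others in the source may bear on it.

Measured so far:
compound 1, `ClCc1ccccc1Cn1cnc2c(Cl)nc(Cl)nc21`, 580 nM
compound 2, `ClCc1cccc(Cn2cnc3c(Cl)nc(Cl)nc32)c1`, 2690 nM
compound 3, `Nc1nc(Cl)c2ncn(Cc3ccccc3CCl)c2n1`, 2950 nM

All three numbers come from a functional assay on NCI-H522 cells (Homo sapiens) for cytotoxicity, read by sulforhodamine B assay, with a stated time of 48 h; a lower number here means a stronger inhibitor of growth, a higher number a weaker inhibitor of growth. Compound 1 and compound 2 are built from the same atoms joined differently; the difference between the two cores is not broken down here. Compound 1 gives the lowest of the three numbers, and compound 2 gives a number beyond the scatter above it. Compound 2 and compound 3 give numbers within the scatter of each other, so nothing separates them.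

One measured step connects compound 1 to compound 3. The change is amino in place of chloro on an aromatic carbon, and it made a 5.1-fold higher number from compound 1 to compound 3 (0.71 log units; beyond the scatter).

Compound 4, `Nc1nc(Cl)c2ncn(Cc3cccc(CCl)c3)c2n1`, has not been measured in this assay. It stands to compound 2 as compound 3 stands to compound 1: the change is amino in place of chloro on an aromatic carbon, and its place line reads word for word as the earlier one, so it is the same change, made here on the core of compound 2 rather than that of compound 1. Among the measured compounds shown here, with only one earlier instance to rest on, the step is expected to be of a similar size, a 4.1-fold higher number from compound 2 to compound 4 (0.61 log units; beyond the scatter), because a 5.1-fold higher number from compound 1 to compound 3 (0.71 log units; beyond the scatter) is the only guide available. Compound 4 is therefore estimated at 11000 nM, likely between 4000 nM and 30000 nM.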

Compound 4, concentration for 50% growth inhibition: 3310 nM
For compound 4 the middle estimate is 3.3-fold (0.52 log units) above the measured one, outside the stated range (below it).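

On the core of compound 2, amino in place of chloro on an aromatic carbon gave a 1.2-fold higher number from compound 2 to compound 4 (0.09 log units; within the scatter) in this assay, so the change leaves no readable effect on this core. Set beside the earlier step, the same change does not carry over at the same size, and the two cores respond differently to it: the same change on two cores in this assay, a 5.1-fold higher number (0.71 log units; beyond the scatter) from compound 1 to compound 3 and a 1.2-fold higher number (0.09 log units; within the scatter) from compound 2 to compound 4, 4.1-fold (0.62 log units) apart, beyond the scatter of two such steps This shows that, for these two cores, a step measured on one is a poor guide to the step on the other, but it does not show what in the cores produces the difference, and with only two instances it cannot say which step, if either, is typical of the series.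

The compounds shown carry only chloro or amino on this aromatic carbon, so it remains open whether a hydroxyl, a methoxy or a methylamino group there would give a large step on one core and a small one on the other. As far as these compounds go, the chloro group meta to this carbon is present in all four compounds, so it also remains open how an amine or a methyl group in its place would read in this assay.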